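Aniline swaps on a shared core in PC-3 cytotoxicity

The source may hold more compounds than are shown below. What is called first, only, known or untested is meant among the compounds shown, and "the series" means these compounds.

Compound 1, `CCCCCCCCNc1nc(SCc2ccc(C(F)(F)F)cc2)nc2ccccc12`, gives 10500 nM.
Compound 2, `FC(F)(F)c1ccc(CSc2nc(Nc3ccccc3Cl)c3ccccc3n2)cc1`, gives 20400 nM.
Compound 3, `O=[N+]([O-])c1cccc(Nc2nc(SCc3ccc(C(F)(F)F)cc3)nc3ccccc23)c1`, gives 13500 nM.

These three compounds were tested in a functional assay on PC-3 cells (Homo sapiens) for cytotoxicity, read by MTT assay, with a stated time of 72 h; on this read-out higher numbers stand for weaker inhibition and lower numbers for stronger inhibition. Compound 3 stands second highest of the three numbers; its nearest neighbour is compound 1, with a 1.3-fold higher number from compound 1 to compound 3 (0.11 log units; within the scatter), and its furthest is compound 2, with a 1.5-fold lower number from compound 2 to compound 3 (0.18 log units; within the scatter). The step of a 1.9-fold higher number from compound 1 to compound 2 (0.29 log units; within the scatter) completes the set, so all three compounds sit within the scatter of one another.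

Compound 4, `Fc1ccc(Nc2nc(SCc3ccc(C(F)(F)F)cc3)nc3ccccc23)cc1Cl`, has not yet been measured. It differs from compound 3 in one place: 3-chloro-4-fluorophenyl in place of 3-nitrophenyl on a nitrogen on an aromatic ring. Within the data shown here, the step that bears most directly on this change is the one from compound 2 to compound 3, where one substituted phenyl on the same nitrogen replaced another and the number moved within the scatter. The steps from compound 1 to compound 2 and to compound 3, where an octyl chain gave way to a substituted phenyl, were likewise within the scatter. On that basis the author expects no step beyond the scatter in this assay, so that the estimated step of a 1.0-fold higher number from compound 3 to compound 4 (0.02 log units; within the scatter) is small. Compound 4 is therefore estimated at 14000 nM, with a range from 6000 nM to 35000 nM.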

Compound 4, half-maximal inhibitory concentration: 18600 nM
Beside the measured number, compound 4's estimate is 1.3-fold (0.12 log units) below it; the range from low to high includes it.
By their numbers in this assay, from the lowest: compounds 1, 3, 4 and 2 (each within the scatter of the next).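

In this assay the change on this nitrogen gives a 1.4-fold higher number from compound 3 to compound 4 (0.14 log units; within the scatter), so a group with 0 hydrogen-bond acceptors and two halogens on its ring reads no differently here from the 3-nitrophenyl group, which has 2 hydrogen-bond acceptors. The other two new steps tell the same story: a 1.1-fold lower number from compound 2 to compound 4 (0.04 log units; within the scatter), and against the octyl chain there is a 1.8-fold higher number from compound 1 to compound 4 (0.25 log units; within the scatter), so a third substituted phenyl joins the earlier groups and all four compounds now sit within the scatter of one another. No measurement shown here speaks to why the numbers stay together in this way.

Every group shown on this nitrogen is either the octyl chain or a substituted phenyl, so it remains open whether a much shorter chain such as methyl, a carboxylic acid on the phenyl ring, or a piperazine in place of the aniline would produce a step beyond the scatter. The rest of the shared core is the same in all four compounds, so these results say nothing about how changes elsewhere on it would read.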